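This account rests on a few compounds, and the source may have more. Where it says the series, first, only, none or still open, it means among the compounds named here.

Compound 1 `CCCCc1nc2ncccc2n1Cc1cc(Cl)c(O)c(Cl)c1` and compound 2 `CCCc1nc2ncccc2n1Cc1cc(Cl)c(O)c(Cl)c1` share one core, while compound 3 `Cc1ccnc2c1nc(C)n2Cc1ccc(-c2ccccc2C(=O)O)cc1` is built on another; the difference between the two cores is not broken down here. In a functional assay (aorta) with Oryctolagus cuniculus as the target (a higher number here means weaker binding, a lower number tighter binding), compound 1 gives 398 nM, compound 2 gives 794 nM and compound 3 gives 50.1 nM. The step of a 2.0-fold lower number from compound 2 to compound 1 (0.30 log units; within the scatter) comes from methyl in place of hydrogen on a saturated chain carbon, three bonds along the chain from an aromatic carbon. Compound 4 `CCc1nc2c(C)ccnc2n1Cc1ccc(-c2ccccc2C(=O)O)cc1` is not yet measured; it carries the same kind of change relative to compound 3, (methyl in place of hydrogen on a saturated chain carbon bound to an aromatic carbon), the place now being a saturated chain carbon bound to an aromatic carbon rather than one three bonds along the chain from it. Because the earlier step of a 2.0-fold lower number from compound 2 to compound 1 (0.30 log units; within the scatter) stayed within the scatter, a similarly modest step is expected for compound 4, estimated as a 1.4-fold lower number from compound 3 to compound 4 (0.16 log units; within the scatter). Compound 4 is therefore expected to give about 35 nM, most likely between 12 nM and 100 nM.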

Compound 4, dissociation constant: 1.26 nM
Beside the measured number, compound 4's estimate is 28-fold (1.44 log units) above it; measured number below the stated range.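

In this assay, methyl in place of hydrogen on a saturated chain carbon bound to an aromatic carbon gives a 40-fold lower number from compound 3 to compound 4 (1.60 log units; beyond the scatter). Among these compounds, the same kind of change therefore does not carry over from one core to the other at a fixed size: the same change on two cores in this assay, a 2.0-fold lower number (0.30 log units; within the scatter) from compound 2 to compound 1 and a 40-fold lower number (1.60 log units; beyond the scatter) from compound 3 to compound 4, 20-fold (1.30 log units) apart, beyond the scatter of two such steps The two steps differ in core and also in the place of the change, so this gap cannot be assigned to either, and each core offers only a single step.

Still open, from the compounds shown here alone, is whether a propyl or butyl chain on the core of compound 3 would extend the large step or reverse it. Also open, going by these compounds, is whether a carboxylic acid on the core of compound 1 would alter the small one.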